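A few compounds are considered here, and "the series" means these few. Any claim that something is new, unique, unknown or untested is made for them only; others in the source may bear on it.

Measured so far in a functional assay on MDA-MB-435S cells (Homo sapiens) for antiproliferative activity, read by MTT assay, with a stated time of 72 h; a lower number here means a stronger inhibitor, a higher number a weaker inhibitor:
Compound 1, `CCOC(=O)c1cc(=O)c2cc(CSC(=S)N(C(C)C)C(C)C)ccc2o1`, gives 8100 nM.
Compound 2, `CCOC(=O)c1cc(=O)c2cc(CSC(=S)N3CCCC3)ccc2o1`, gives 3400 nM.
Compound 3, `CN(C(=S)SCc1coc2ccccc2c1=O)c1ccccc1`, is recorded only as a limit of the assay, > 25000 nM.

Among the two numbers in hand, compound 2 holds the lowest. Its nearest neighbour is compound 1, and the step of a 2.4-fold lower number from compound 1 to compound 2 (0.38 log units; beyond the scatter) is modest but beyond the scatter. Compound 3 stands at the limit of > 25000 nM in this assay, at which 1 of the 3 values shown sits, so it offers no number against which compound 2 can be ranked.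

Compound 4 is `CCOC(=O)c1cc(=O)c2cc(CSC(=S)N3CCOCC3)ccc2o1`. Against compound 2 it differs in one place: morpholin-4-yl in place of pyrrolidin-1-yl on a thiocarbonyl carbon. Among the compounds with values here, the only measured step that touches this position is a 2.4-fold lower number from compound 1 to compound 2 (0.38 log units; beyond the scatter), where one amine on the thiocarbonyl carbon gave way to another and the number moved modestly. Within the data shown here, no measured step involves morpholin-4-yl itself, so the size of the coming step rests on that one precedent alone. Exchanging one cyclic amine for another at this position is expected to move the number by little, if at all, with a lean toward a higher value. Compound 4 is therefore estimated at 5000 nM, within a range from 2000 nM to 15000 nM. That estimate corresponds to an expected step of a 1.5-fold higher number from compound 2 to compound 4 (0.17 log units; within the scatter).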

Compound 4, half-maximal inhibitory concentration: > 25000 nM
Compound 4: only a limit was reported; the forecaster's own chance of this, stated with the estimate: 10%; middle value at least 5.0-fold (0.69 log units) from the limit.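

Compound 4 is recorded in this assay only as a limit, not as a number, so its result fixes one side of the change and no more: the limit of > 25000 nM in this assay, at which 2 of the 4 values shown sit. Even so, the amine on the thiocarbonyl carbon proves to matter more than the earlier pair suggested, with the change to morpholin-4-yl giving an at least 7.3-fold higher number from compound 2 to compound 4 (0.86 log units; beyond the scatter), and the comparison with the open-chain amine giving an at least 3.0-fold higher number from compound 1 to compound 4 (0.48 log units; beyond the scatter). Having a ring on this nitrogen therefore does not decide the outcome among these compounds, since compound 1 with diisopropylamino and compound 2 with pyrrolidin-1-yl both give numbers, while compound 4, which also carries a cyclic amine, reaches only the limit.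

The compounds shown leave open whether the six-membered ring or its oxygen accounts for the step, since morpholin-4-yl brings both at once, and piperidin-1-yl, a six-membered ring with carbon in place of that oxygen, would separate the two. Also open, as far as these compounds go, is how far the true number of compound 4 lies past its limit.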